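This account rests on a few compounds, and the source may have more. Where it says the series, first, only, none or still open, it means among the compounds named here.

Compound 2 `COc1ccc(-c2nnc(Cn3nnc4ccccc43)o2)cc1` in an ADME assay on cells (Macrophage, Homo sapiens) for inhibition (on this read-out lower numbers stand for higher toxicity in this test and higher numbers for lower toxicity in this test), gives > 100000 nM, which is a limit of the assay rather than a number. Compound 1 `Brc1ccc(-c2nnc(Cn3nnc4ccccc43)o2)cc1` gives > 100000 nM in this assay, again a limit. The step that the two limits leave unreadable from compound 1 to compound 2 therefore cannot be read in size. Both values sit at the same limit (the limit of > 100000 nM in this assay, at which 2 of the 2 values shown sit), so compound 2 stands at the upper edge of what this assay reports, with nothing to separate it from compound 1. Compound 3 `O=[N+]([O-])c1ccc(-c2nnc(Cn3nnc4ccccc43)o2)cc1` differs from compound 2 by nitro in place of methoxy on an aromatic carbon. Among the measured compounds shown here, the only measured step, from compound 1 to compound 2, bears on this change merely by showing that a swap at the same position left the limit in place; its size is unknown. In this assay the step that the limit leaves unreadable from compound 2 to compound 3 is expected to be none beyond the scatter, with compound 3 expected at 150000 nM, estimated between 50000 nM and 500000 nM, most likely again reported as a limit.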

Compound 3, half-maximal cytotoxic concentration: > 100000 nM
Compound 3 gave a limit, no number (the forecaster's own chance of this, stated with the estimate: 80%); the middle value is on the limit's open side.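

No step among compound 1, compound 2 and compound 3 can be read in this assay, as each value is a limit and not a number: the limit of > 100000 nM in this assay, at which 3 of the 3 values shown sit.

Still open, as far as these compounds go, is whether bromo, methoxy and nitro differ at all on this read-out, and at what concentration, if any, these compounds become toxic to the cells.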